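The source may report more compounds than this note shows. Statements on the series, on what has been measured and on what is new or still open speak of the compounds shown alone.

Three compounds built on one shared core differ in the group carried on a carbonyl carbon, and all three have been tested in an ADME assay on HepG2 2.2.15 cells (Homo sapiens) for cytotoxicity; a higher number here means that more compound is tolerated, a lower number that less compound is tolerated. Compound 1 `O=C(CCC1CCCCC1)OCCc1c(-c2ccccc2Cl)c2cc(Cl)ccc2[nH]c1=O` gives 160000 nM, and compound 2 `O=C(CCOc1ccccc1)OCCc1c(-c2ccccc2Cl)c2cc(Cl)ccc2[nH]c1=O` gives 46000 nM. The gap between these two is a 3.5-fold lower number from compound 1 to compound 2 (0.54 log units; beyond the scatter).

Compound 3 `O=C(/C=C/c1ccc(C(F)(F)F)cc1)OCCc1c(-c2ccccc2Cl)c2cc(Cl)ccc2[nH]c1=O` gives > 1400000 nM, which is a limit and not a number. It stands highest of the three, with steps of an at least 8.7-fold higher number from compound 1 to compound 3 (0.94 log units; beyond the scatter) and an at least 30-fold higher number from compound 2 to compound 3 (1.48 log units; beyond the scatter).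

Compound 4 `C/C=C/C(=O)OCCc1c(-c2ccccc2Cl)c2cc(Cl)ccc2[nH]c1=O` has not yet been measured. Its difference from compound 3 is methyl in place of 4-(trifluoromethyl)phenyl on a double-bonded chain carbon bound to a double-bonded chain carbon. The double-bonded chain carbons stay, but the 4-(trifluoromethyl)phenyl group goes. Among the measured compounds shown here, no measured step makes exactly this swap, so the two steps into compound 3 are the nearest guide. Each of them brings in the 2-(4-(trifluoromethyl)phenyl)ethenyl group, and compound 1 and compound 2, which lack it, both sit well lower. Compound 4 lacks it too, so a clear fall towards their level is expected, of modest to large size, with an estimated at least 7.0-fold lower number from compound 3 to compound 4 (0.84 log units; beyond the scatter). For the measured compounds named here, only three compounds support this, so the range stays wide.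

The estimated value for compound 4 is 200000 nM, expected to lie between 40000 nM and 1000000 nM.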

Compound 4, half-maximal cytotoxic concentration: 30000 nM
Compound 4: the middle estimate sits 6.7-fold (0.82 log units) above what was measured, outside the stated range (below it).
By their numbers in this assay, from the lowest: compounds 4 and 2 (each within the scatter of the next); then compound 1. At a limit, above all of these: compound 3.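

In this assay, the double-bonded chain carbons stay while methyl replaces 4-(trifluoromethyl)phenyl, giving an at least 46-fold lower number from compound 3 to compound 4 (1.66 log units; beyond the scatter), so the double-bonded chain carbons on their own do not bring the high tolerance seen with compound 3, and among the four compounds shown, only the one with the 4-(trifluoromethyl)phenyl group reaches it. The comparison with the phenoxy group gives a 1.5-fold lower number from compound 2 to compound 4 (0.19 log units; within the scatter), which is no real difference, while the comparison with the cyclohexyl group gives a 5.3-fold lower number from compound 1 to compound 4 (0.73 log units; beyond the scatter), so the small prop-1-en-1-yl group does not lift the number above those of the two saturated chains. The value of compound 3 is a limit and not a number, so the full size of its step stays unknown: the limit of > 1400000 nM in this assay, at which 1 of the 4 values shown sits.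

Still open, on these data alone, is whether the high tolerance goes with the trifluoromethyl group or with the aromatic ring itself, a question that a plain phenyl group at this place would help to settle. As far as these compounds go, it is also open whether the double-bonded chain carbons matter once the 4-(trifluoromethyl)phenyl group is present, which a saturated ethyl chain carrying that same group would show.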